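A few compounds are considered here, and "the series" means these few. Any claim that something is new, unique, unknown or untested is made for them only; others in the source may bear on it.

Measured so far in a functional assay on the whole organism (Tail, strain ICR) with Mus musculus as the target, in the tail flick test, with a stated time of 60 min, at a dose of 25 umol/kg by the oral route; on this read-out lower numbers stand for a weaker effect and higher numbers for a stronger effect at the one dose given:
compound 1, `NC(=O)CC[C@H](NC(=O)CN(c1ncnc2c1ncn2C1CCCCO1)C1CC1)C(=O)OCc1ccccc1`: 39.4%
compound 2, `O=C(O)CC[C@H](NC(=O)CN(c1nc(Cl)nc2[nH]cnc12)C1CC1)C(=O)O`: 33.3%

Compound 2 holds the lower of the two numbers in hand. The nearest figure belongs to compound 1, which in this assay gives 39.4%; the gap between the two lies within the scatter of repeated measurements, so the two compounds are not told apart on this read-out. Going by the values given here, they also differ in more than one place, so no single step between them can be set out, and nothing about the effect of any one exchange can be drawn from the pair.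

Compound 3, `CSCC[C@H](NC(=O)CN(c1nc(Cl)nc2[nH]cnc12)C1CC1)C(=O)O`, has not yet been measured. It differs from compound 2 in one place: methylsulfanyl in place of carboxy on a saturated chain carbon, three bonds along the chain from an amide-type nitrogen and a carbonyl carbon. The change sits on a saturated chain carbon, three bonds along the chain from an amide-type nitrogen and a carbonyl carbon. Among the compounds with values here, no measured pair shows the effect of this exchange, so the size of the step in this assay cannot be read from the data in hand. The expectation is of no step beyond the scatter in either direction, the estimated step being a number 0.3 percentage points lower from compound 2 to compound 3 (within the scatter). Compound 3 is accordingly expected to give 33%, with a range from 15% to 52%.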

Compound 3, a percentage reported as activity, at one dose (the size of the read-out at that dose, not a potency): 22.8%
Beside the measured number, compound 3's estimate is 10.2 percentage points above it; the range from low to high includes it.
By their numbers in this assay, from the lowest: compound 3; then compounds 2 and 1 (each within the scatter of the next).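

In this assay, going by these compounds alone, this is the first exchange that can be read at this place, a saturated chain carbon, three bonds along the chain from an amide-type nitrogen and a carbonyl carbon: methylsulfanyl in place of carboxy gives a number 10.5 percentage points lower from compound 2 to compound 3 (beyond the scatter), a modest step. The read-out at this one dose therefore responds to what stands at this place, at least for this exchange on the core of compound 2, and the carboxy is not interchangeable here with methylsulfanyl. The exchange takes out a hydrogen-bond donor and brings in sulfur while the hydrogen-bond acceptor count stays the same, but nothing measured here bears on the reason for the step.

The compounds shown leave open whether the step belongs to the loss of the carboxy or to the entry of the sulfur, which a plain methyl, an amine or a primary amide at the same place on the core of compound 2 would help to separate. Also open, as far as these compounds go, is whether a longer chain carrying the carboxy or the methylsulfanyl would move the number at all, and whether a step of this size would hold at other doses and times.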